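This account rests on a few compounds, and the source may have more. Where it says the series, first, only, none or still open, it means among the compounds named here.

Series notes, amide substituent on the shared core.

Compound 1 `CC(=O)N1CC2CC(C1)N2` carries an acetyl group on the shared core. In an assay on CHO cells for displacement of a labelled ligand from Neuronal acetylcholine receptor; alpha3/alpha6/beta2/beta3 (Homo sapiens), read by scintillation counting (a lower number here means a stronger inhibitor, a higher number a weaker inhibitor), compound 1 gives 610 nM. Among the three numbers measured so far this is the second highest; the nearest is compound 2 `CC(C)C(=O)N1CC2CC(C1)N2`, which in this assay gives 580 nM, and the furthest is compound 3 `O=C(C1CC=CC1)N1CC2CC(C1)N2`, which in this assay gives 1100 nM. Both gaps to compound 1 sit within the scatter of the method, so no ordering among the three is claimed.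

For the measured compounds named here, the only measured step that bears on a change at the acyl position is a 1.1-fold lower number from compound 1 to compound 2 (0.02 log units; within the scatter), which has no effect beyond the scatter. Going by the values given here, no step is tabulated between compound 1 and compound 3; their two values show a gap that also stays within the scatter.

Compound 4 `O=C(CC1C=CCC1)N1CC2CC(C1)N2` is not yet measured. It differs from compound 1 by cyclopent-2-en-1-yl in place of hydrogen on a saturated chain carbon bound to a carbonyl carbon. The single measured enlargement at this position, from compound 1 to compound 2, did not move this assay, and the values of compound 1 and compound 3 bracket a larger group on the carbonyl without a clear shift, so for compound 4 the step of a 1.2-fold higher number from compound 1 to compound 4 (0.09 log units; within the scatter) is expected to stay small. Compound 4 is estimated at 750 nM in this assay, with a range from 300 nM to 1900 nM.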

Compound 4, inhibition constant: 2500 nM
Compound 4: the middle estimate sits 3.3-fold (0.52 log units) below what was measured; measured number above the stated range.
By their numbers in this assay, from the lowest: compounds 2, 1 and 3 (each within the scatter of the next); then compound 4.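

Cyclopent-2-en-1-yl in place of hydrogen on a saturated chain carbon bound to a carbonyl carbon gives a 4.1-fold higher number from compound 1 to compound 4 (0.61 log units; beyond the scatter) in this assay and is the first change in this series shown to move the number beyond the scatter, though the step is modest. The other measured step on the acyl group is a 1.1-fold lower number from compound 1 to compound 2 (0.02 log units; within the scatter) and shows no such shift, so enlarging the acyl group does not leave this assay unmoved in every case: isopropyl in place of methyl on a carbonyl carbon changes nothing that can be read, whereas the cyclopent-2-en-1-yl change raises the number. The data shown give no reason for this difference between the two steps.

The compounds shown do not separate the contribution of the ring from that of its double bond, and a saturated cyclopentyl group at the same place would bear directly on that point. From the compounds shown here alone, whether ring size or the mere length of the acyl group matters also stays open, and a straight butyl chain or a cyclohexyl group on the same chain carbon would speak to it.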